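Removing the chloromethyl from the urea side chain

The source may report more compounds than this note shows. Statements on the series, on what has been measured and on what is new or still open speak of the compounds shown alone.

Measured compounds and their values:
compound 1 `CCc1ccccc1NS(=O)(=O)c1ccc(NC(=O)NCCCCl)cc1` — > 200000 nM
compound 2 `CCCc1ccccc1NS(=O)(=O)c1ccc(NC(=O)NCCCCl)cc1` — 35000 nM

Compound 1 stands only at a limit in a functional assay on MCF7 cells (Homo sapiens) for cytotoxicity, read by sulforhodamine B assay, with a stated time of 48 h; on this read-out lower numbers stand for stronger inhibition and higher numbers for weaker inhibition: its value of > 200000 nM is a limit of the assay and not a number (the limit of > 200000 nM in this assay, at which 1 of the 2 values shown sits). Going by the values given here, compound 2, which carries methyl in place of hydrogen on a saturated chain carbon, two bonds along the chain from an aromatic carbon, gives 35000 nM in this assay, so the step of an at least 5.7-fold lower number from compound 1 to compound 2 (0.75 log units; beyond the scatter) is the only measured comparison.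

Compound 3 `CCNC(=O)Nc1ccc(S(=O)(=O)Nc2ccccc2CC)cc1` is not yet measured. It differs from compound 1 by hydrogen in place of chloromethyl on a saturated chain carbon, two bonds along the chain from an amide-type nitrogen; read one bond further out, 3-chloropropyl becomes ethyl, so the (3-chloropropyl)amino of the urea becomes ethylamino. Among the compounds with values here, no measured step touches this end of the molecule; the one step known, from compound 1 to compound 2, concerns the other side of the shared core and says nothing about the urea chain. Compound 3 is therefore expected near the limit as well, with the estimated step that the limit leaves unreadable from compound 1 to compound 3 being none beyond the scatter. The expected value for compound 3 in this assay is 250000 nM, with a range of 50000 nM to 1000000 nM, and most likely only a limit will again be reported.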

Compound 3, half-maximal inhibitory concentration: 91000 nM
The estimate for compound 3 lay 2.7-fold (0.44 log units) above the measured number; low and high end bracket the measured number.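

In this assay, the urea end of the series now has a step of its own: hydrogen in place of chloromethyl on a saturated chain carbon, two bonds along the chain from an amide-type nitrogen, gives an at least 2.1-fold lower number from compound 1 to compound 3 (0.34 log units; beyond the scatter). The chlorine-bearing chain end is therefore not required for a measurable read-out, since compound 3, with ethylamino in place of (3-chloropropyl)amino, gives 91000 nM in this assay. The full size of the step cannot be read because compound 1 stands at a limit and not at a number: the limit of > 200000 nM in this assay, at which 1 of the 3 values shown sits.

Compound 2 and compound 3 differ in more than one place, so the compounds shown do not tell whether the change on the other side of the shared core and the change at the urea chain would add up in one molecule. Also open, on these data alone, is whether the chain length or the chlorine accounts for the step, which a chlorine-free chain of the same length, such as propyl, or a chain ending in a hydroxyl or an amine, would help to separate.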